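The compounds below may be only part of what the source reports. "The series", "measured", "known", "first", "only" and "open" are said of these compounds alone.

Measured so far:
compound 1, `Cc1ccccc1OS(=O)(=O)c1ccc(N2CCN(C)C2=O)cc1`: 2900 nM
compound 2, `CCCN1CCN(c2ccc(S(=O)(=O)Oc3ccccc3C)cc2)C1=O`: > 100000 nM

In a functional assay on M21 cells (Homo sapiens) for antiproliferative activity, read by sulforhodamine B assay, with a stated time of 48 h (a lower number here means a stronger inhibitor, a higher number a weaker inhibitor), compound 1 gives 2900 nM. Compound 2 returns only a limit of the assay, > 100000 nM (the limit of > 100000 nM in this assay, at which 1 of the 2 values shown sits). Among the measured compounds shown here, the one measured step, an at least 34-fold higher number from compound 1 to compound 2 (1.53 log units; beyond the scatter), therefore ends in a limit, so compound 2 stands at the weak end of what can be read here.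

Compound 3, `CCCN1CCN(c2ccc(S(=O)(=O)Oc3cccc(OC)c3)cc2)C1=O`, differs from compound 2 by 3-methoxyphenyl in place of 2-methylphenyl on an oxygen. No measured step touches this part of the molecule; the only step shown concerns the chain on the ring nitrogen, which compound 3 keeps. Nothing therefore points to a change beyond the scatter, and a limit is again likely. Compound 3 is estimated at 100000 nM, range 20000 nM to 300000 nM, meaning an expected step of a number no higher from compound 2 to compound 3 (the limit leaves the size open).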

Compound 3, half-maximal inhibitory concentration: 10000 nM
Compound 3: the middle estimate sits 10-fold (1.00 log units) above what was measured; the whole stated range lies above it.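

The aryl group on the oxygen bound to the sulfonyl sulfur is a place that moves the read-out in this assay: 3-methoxyphenyl in place of 2-methylphenyl gives an at least 10-fold lower number from compound 2 to compound 3 (1.00 log units; beyond the scatter). With the chain on the ring nitrogen unchanged, that chain does not by itself exclude a readable value. The size of this step stays open, as the value of compound 2 is a limit: the limit of > 100000 nM in this assay, at which 1 of the 3 values shown sits.

On these data alone, whether 3-methylphenyl or 2-methoxyphenyl would read like 3-methoxyphenyl remains open. So does the effect of an amine or a carboxylic acid on this ring.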